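The source may hold more compounds than are shown below. What is called first, only, known or untested is meant among the compounds shown, and "the series" means these compounds.

Of the compounds shown here, two built on the same urea core have been measured so far. Compound 1, `Cc1cccc(C)c1NC(=O)Nc1ccncc1`, tested in a functional assay on the whole organism with Mus musculus as the target, in the maximal electroshock model, with a stated time of 30 min (on this read-out higher numbers stand for an effect only at larger amounts of compound and lower numbers for an effect already at smaller amounts), gives 30 mg/kg. Compound 2, `O=C(Nc1ccncc1)Nc1c(Cl)cccc1Cl`, tested in this assay gives 100 mg/kg. Among the measured compounds shown here, of the two numbers, compound 2 stands highest, and its only neighbour, compound 1, sits at a lower number by a margin beyond the usual scatter, so compound 1 is the more potent of the pair on this read-out.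

The next compound, compound 3, `Cc1cccc(Cl)c1NC(=O)Nc1ccncc1`, has not yet been measured. Relative to compound 2 the change is methyl in place of chloro on an aromatic carbon. For the measured compounds named here, no pair of measured compounds isolates this single exchange: compound 1 carries two methyl groups, compound 2 carries two chloro groups, and compound 3 holds one of each, so it lies structurally between them.

On that basis the number for compound 3 in this assay is expected to fall between the two measured values, giving an expected downward step of a 1.8-fold lower number from compound 2 to compound 3 (0.26 log units; within the scatter) from compound 2. The estimate for compound 3 is 55 mg/kg, with a range from 25 mg/kg to 120 mg/kg.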

Compound 3, minimum effective dose: 30 mg/kg
Compound 3: the middle estimate sits 1.8-fold (0.26 log units) above what was measured; the range from low to high includes it.
By their numbers in this assay, from the lowest: compounds 1 and 3 (each within the scatter of the next); then compound 2.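

In this assay, among the compounds shown here, methyl in place of chloro on an aromatic carbon, with a chloro group remaining on the ring, gives a 3.3-fold lower number from compound 2 to compound 3 (0.52 log units; beyond the scatter), the first single exchange in this set that can be read on its own, and it lies beyond the scatter. The related exchange of chloro in place of methyl, this time with a methyl group remaining on the ring, gives no change at the digits printed from compound 1 to compound 3 (within the scatter), so among these three compounds swapping methyl and chloro shifts the number in one setting and not in the other, and its size depends on which group stays on the ring. Nothing available here bears on why these two steps differ.

The compounds shown leave open how a bromo group, a methoxy group or an ethyl group would compare with methyl and chloro at this place on the ring. They also leave open whether this dependence on the remaining group would hold beyond these two steps, which are all that can be read so far.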